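The compounds below may be only part of what the source reports. "The series", "measured", "known", "first", "only" and "open" are said of these compounds alone.

In a functional assay on the whole organism for permeability, with Rattus norvegicus as the target, with a stated time of 4 h (on this read-out higher numbers stand for an effect only at larger amounts of compound and lower numbers for an effect already at smaller amounts), compound 1 `CCCCn1cc(C2CCN(Cc3cccc(C(=O)O)c3)CC2)c2ccccc21` gives 1 mg/kg, while compound 2 `CCCCn1cc(C2CCN(Cc3ccc(OC)c(C(=O)O)c3)CC2)c2ccccc21` gives 0.08 mg/kg, the lower of the two numbers. These compounds differ in one place, a methoxy in place of hydrogen on an aromatic carbon, and the result is a 13-fold lower number from compound 1 to compound 2 (1.10 log units; beyond the scatter).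

Compound 3 `COc1ccc(CN2CCC(c3cn(Cc4ccc(Cl)s4)c4ccccc34)CC2)cc1C(=O)O` keeps that methoxy but changes another place, with 5-chlorothiophen-2-yl in place of propyl on a saturated chain carbon bound to an aromatic nitrogen. Among the measured compounds shown here, the one measured step, although large, concerns the methoxy, and no measured pair tests the new change. The expectation therefore starts from compound 2 at 0.08 mg/kg, and no step beyond the scatter is predicted, though the uncertainty is wide. The expected result is a 1.9-fold higher number from compound 2 to compound 3 (0.27 log units; within the scatter). For compound 3 the estimated value is 0.15 mg/kg, with an expected range from 0.03 mg/kg to 0.8 mg/kg.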

Compound 3, dose for half-maximal effect: 0.5 mg/kg
Compound 3: middle estimate off by 3.3-fold (0.52 log units), on the low side, and the stated range covers the measured number.
By their numbers in this assay, from the lowest: compound 2; then compounds 3 and 1 (each within the scatter of the next).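

The group on this saturated chain carbon bound to an aromatic nitrogen does matter in this assay: 5-chlorothiophen-2-yl in place of propyl gives a 6.3-fold higher number from compound 2 to compound 3 (0.80 log units; beyond the scatter). So this place responds to change as well as the methoxy place does, and here the swap from a plain chain to a chlorine-bearing aromatic ring moves the number upward, though compound 3 still gives a measurable dose of 0.5 mg/kg. Nothing available explains why this swap raises the number.

From the compounds shown here alone, with only these two groups at this place, it stays open whether the ring or its chlorine accounts for the step, which an unsubstituted thiophen-2-yl or a phenyl ring would help to separate. A shorter chain such as ethyl would show how the number follows chain length.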